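The source may report more compounds than this note shows. Statements on the series, on what has been measured and on what is new or still open speak of the compounds shown alone.

In a functional assay on K562 cells (Homo sapiens), read by MTT assay, with a stated time of 72 h (a lower number here means a stronger inhibitor, a higher number a weaker inhibitor), compound 1 `COc1ncnc2c1c(-c1ccccc1)cn2[C@@H]1O[C@H](CO)[C@@H](O)[C@H]1O` gives > 20000 nM, which is a limit of the assay and not a number. Compound 3 `CSc1ncnc2c1c(-c1ccccc1)cn2[C@@H]1O[C@H](CO)[C@@H](O)[C@H]1O` has methylsulfanyl in place of methoxy on an aromatic carbon. Compound 2 `CSc1ncnc2c1c(-c1ccsc1)cn2[C@@H]1O[C@H](CO)[C@@H](O)[C@H]1O`, which also bears methylsulfanyl, gives 450 nM in this assay, so some gain in strength is expected, though this single value is thin support. The expected change is an at least 3.3-fold lower number from compound 1 to compound 3 (0.52 log units; beyond the scatter), a step toward a stronger inhibitor of uncertain size, and compound 3 may still reach the limit. For compound 3 the estimated value is 6000 nM, with an expected range of 1000 nM to 20000 nM.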

Compound 3, half-maximal inhibitory concentration: > 20000 nM
Compound 3: only a limit was reported (the forecaster's own chance of this, stated with the estimate: 45%); middle value at least 3.3-fold (0.52 log units) from the limit.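

Methylsulfanyl in place of methoxy on this aromatic carbon gives no readable gain in this assay, and the step between compound 1 and compound 3 cannot be read: the limit of > 20000 nM in this assay, at which 2 of the 3 values shown sit.

With methylsulfanyl held constant, phenyl in place of thiophen-3-yl gives an at least 44-fold higher number from compound 2 to compound 3 (1.64 log units; beyond the scatter). Methylsulfanyl alone therefore does not carry the strength of compound 2, and that strength depends on thiophen-3-yl in this pair.

From the compounds shown here alone, whether thiophen-3-yl keeps that strength with methoxy or an amine in place of methylsulfanyl remains open. So does the effect of furan-3-yl in its place.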